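Sulfamoylamino benzamides: removing the sulfonamide methyl

This account rests on a few compounds, and the source may have more. Where it says the series, first, only, none or still open, it means among the compounds named here.

Compound 1 `CCN1CCCC1CNC(=O)c1cc(NS(=O)(=O)N(C)C)c(Cl)cc1OC` is measured in a functional assay on the whole organism for inhibition, with Canis familiaris (Canis lupus familiaris) as the target (on this read-out higher numbers stand for an effect only at larger amounts of compound and lower numbers for an effect already at smaller amounts), where compound 1 gives 0.05 mg/kg. Compound 3 `CCN1CCCC1CNC(=O)c1cc(NS(=O)(=O)NC)c(Cl)cc1OC` differs from it by hydrogen in place of methyl on a sulfonamide nitrogen. In this assay compound 3 reaches only a limit, > 1 mg/kg. The step of an at least 20-fold higher number from compound 1 to compound 3 (1.30 log units; beyond the scatter) is therefore a loss. Compound 2 `CCN1CCCC1CNC(=O)c1cc(NS(=O)(=O)NC)ccc1OC` has a core whose difference from compound 1 is not broken down here. In this assay compound 2 gives only a limit, > 1 mg/kg. Two of the three values sit at the limit of > 1 mg/kg in this assay, at which 2 of the 3 values shown sit. Compound 4 `CCN1CCCC1CNC(=O)c1cc(NS(N)(=O)=O)ccc1OC` carries hydrogen in place of methyl on a sulfonamide nitrogen, the same kind of change as that between compound 1 and compound 3, here on a sulfonamide nitrogen whose other neighbour is the sulfonyl sulfur alone rather than a saturated chain carbon and a sulfonyl sulfur. For compound 4 a step that the limit leaves unreadable from compound 2 to compound 4 is expected in this assay. That expectation rests on the direction of an at least 20-fold higher number from compound 1 to compound 3 (1.30 log units; beyond the scatter) and on compound 2 already standing at the limit. Compound 4 is accordingly estimated at 5 mg/kg, between 1 mg/kg and 30 mg/kg, most probably reported again only as a limit.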

Compound 4, dose for half-maximal effect: 10 mg/kg
Compound 4: middle estimate off by 2.0-fold (0.30 log units), on the low side; measured number inside the range.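

In this assay no new step can be read from compound 2 to compound 4; the value of compound 2 is only a limit. As far as these compounds go, whether hydrogen in place of methyl on this sulfonamide nitrogen changes the number at all remains open.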